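Sulfoxide series: heteroaryl swap from compound 1 to compound 4

The source may report more compounds than this note shows. Statements on the series, on what has been measured and on what is new or still open speak of the compounds shown alone.

Measured so far:
compound 1 `Cc1scc(C[S+]([O-])C(c2ccccc2)c2ccccc2)c1C` — 284000 nM
compound 2 `Cc1cc(O)nc(C[S+]([O-])C(c2ccccc2)c2ccccc2)n1` — 109000 nM
compound 3 `COc1ccnc(C[S+]([O-])C(c2ccccc2)c2ccccc2)c1OC` — "not active" (no number reported)

In an assay on HEK293 cells for inhibition of sodium-dependent dopamine transporter (Homo sapiens), read by scintillation counting, with stated times of 5 min and 1 min (a higher number here means a weaker inhibitor, a lower number a stronger inhibitor), compound 1 holds the highest of the two numbers; its nearest neighbour is compound 2, with a 2.6-fold lower number from compound 1 to compound 2 (0.42 log units; beyond the scatter). Compound 3 is reported as "not active" (no number reported) and supplies no number.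

Compound 4 `O=c1[nH]nc(C[S+]([O-])C(c2ccccc2)c2ccccc2)s1` differs from compound 1 by a group of 6 heavy atoms (2 carbon, 2 nitrogen, 1 oxygen, 1 sulfur; one five-membered aromatic ring with 3 hetero atoms) in place of a group of 7 heavy atoms (6 carbon, 1 sulfur; one five-membered aromatic ring with 1 hetero atom), on a saturated chain carbon bound to a sulfur. Among the compounds with values here, the only step that bears on it is the one from compound 1 to compound 2, also a heteroaryl exchange on the same saturated chain carbon, and that step was modest. A step of similar or smaller size is therefore expected in this assay, most likely toward a lower number, though a step within the scatter is equally plausible. Compound 4 is estimated at 180000 nM (range 60000 nM to 600000 nM), meaning an expected step of a 1.6-fold lower number from compound 1 to compound 4 (0.20 log units; within the scatter).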

Compound 4, half-maximal inhibitory concentration: 38100 nM
Beside the measured number, compound 4's estimate is 4.7-fold (0.67 log units) above it, outside the stated range (below it).
By their numbers in this assay, from the lowest: compound 4; then compound 2; then compound 1.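

The change to the group in compound 4 gives a 7.5-fold lower number from compound 1 to compound 4 (0.87 log units; beyond the scatter) in this assay, and also a 2.9-fold lower number from compound 2 to compound 4 (0.46 log units; beyond the scatter), so the heteroaryl group on the saturated chain carbon can lower the number further than compound 2 showed. Compound 1 and compound 4 both carry a five-membered aromatic ring with different hetero atoms, so ring size alone does not set the number here.

Going by these compounds, whether a carboxylic acid or an amine at this place would go lower remains open. Nothing shown explains the steps.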